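The compounds below may be only part of what the source reports. "The series", "measured", "known", "first", "only" and "open" are said of these compounds alone.

The three measured compounds share one core and differ only in the aryl group on the carbon that carries a double bond to nitrogen. Compound 1 `Cc1c(C(=O)N/N=C\c2ccccc2C(F)(F)F)oc2cccc(O)c12` gives 26200 nM in a functional assay on PC-3 cells (Homo sapiens) for inhibition; a higher number here means a weaker inhibitor, a lower number a stronger inhibitor. Compound 2 `Cc1c(C(=O)N/N=C\c2ccc(O)cc2)oc2cccc(O)c12` gives 21700 nM there, and compound 3 `Cc1c(C(=O)N/N=C\c2cccc(O)c2O)oc2cccc(O)c12` gives 12200 nM. Compound 2 thus holds the second highest of the three numbers, sitting within the scatter of compound 1 and also within the scatter of compound 3.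

The unmeasured compound 4 `COc1ccccc1/C=N\NC(=O)c1oc2cccc(O)c2c1C` differs from compound 2 by 2-methoxyphenyl in place of 4-hydroxyphenyl on a carbon with a double bond to nitrogen. For the measured compounds named here, no measured pair swaps a hydroxyphenyl for a methoxyphenyl, so the only bearing step is a 1.8-fold lower number from compound 2 to compound 3 (0.25 log units; within the scatter), which itself stayed within the scatter, and the three numbers as a whole span a narrow band. Compound 4 is therefore expected to sit close to compound 2, with an expected step of a 1.2-fold higher number from compound 2 to compound 4 (0.06 log units; within the scatter) and no shift beyond the scatter in either direction. The estimate for compound 4 in this assay is 25000 nM, within a range from 10000 nM to 60000 nM.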

Compound 4, half-maximal inhibitory concentration: 32700 nM
For compound 4 the middle estimate is 1.3-fold (0.12 log units) below the measured one; the range from low to high includes it.
By their numbers in this assay, from the lowest: compounds 3, 2, 1 and 4 (each within the scatter of the next, the first and the last beyond it).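

In this assay, for the compounds shown here, the 2-methoxyphenyl group gives the first step at this position to pass the scatter, a 2.7-fold higher number from compound 3 to compound 4 (0.43 log units; beyond the scatter) with 2-methoxyphenyl in place of 2,3-dihydroxyphenyl on the carbon with a double bond to nitrogen. The other two steps stay inside the scatter, a 1.5-fold higher number from compound 2 to compound 4 (0.18 log units; within the scatter) for the exchange of 4-hydroxyphenyl and a 1.2-fold higher number from compound 1 to compound 4 (0.10 log units; within the scatter) for methoxy in place of trifluoromethyl, so compound 4 cannot be told apart from compound 1 or compound 2. Nothing measured here accounts for the separation of compound 3 from compound 4.

The compounds shown leave open which part of the 2,3-dihydroxyphenyl group goes with that separation. Also open, on these data alone, is how an aryl group carrying an amine or a carboxylic acid would read at this carbon.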